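The source may report more compounds than this note shows. Statements on the series, on what has been measured and on what is new or still open speak of the compounds shown alone.

The shared core is a pyrazole-type scaffold carrying an amide, and the three measured compounds differ only in the aromatic group attached to the carbonyl carbon. Compound 1 `Cc1ccc(C(=O)Nc2cc(-c3ccccc3)nn2-c2ccccc2)cc1` gives 30 nM in an assay on CHO cells with metabotropic glutamate receptor 5 (Homo sapiens) as the target; a lower number here means that less compound is needed, a higher number that more compound is needed for the effect. Compound 2 `O=C(Nc1cc(-c2ccccc2)nn1-c1ccccc1)c1ccccc1` gives 40 nM in this assay, and compound 3 `O=C(Nc1cc(-c2ccccc2)nn1-c1ccccc1)c1ccccc1F` gives 75 nM. On these numbers compound 3 carries the highest value of the three; its gap to compound 2 lies within the scatter, while the step of a 2.5-fold higher number from compound 1 to compound 3 (0.40 log units; beyond the scatter) lies beyond it.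

Compound 4 `Cc1cccc(C(=O)Nc2cc(-c3ccccc3)nn2-c2ccccc2)c1` has not yet been measured. Its change from compound 3 is 3-methylphenyl in place of 2-fluorophenyl on a carbonyl carbon. Among the measured compounds shown here, two measured steps bear on it. The step of a 1.9-fold higher number from compound 2 to compound 3 (0.27 log units; within the scatter) shows what the fluoro contributed, and compound 4 gives that fluoro up again. The step of a 1.3-fold higher number from compound 1 to compound 2 (0.12 log units; within the scatter) shows that swapping a methyl for hydrogen on the aromatic ring changed little, so adding a methyl back is not expected to move the number much. Taken together, compound 4 is expected to land a little below compound 3, near compound 2, with an expected step of a 1.9-fold lower number from compound 3 to compound 4 (0.27 log units; within the scatter). For compound 4 the estimate in this assay is 40 nM, with a range from 20 nM to 80 nM.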

Compound 4, half-maximal effective concentration: 90 nM
The estimate for compound 4 lay 2.3-fold (0.35 log units) below the measured number; measured number above the stated range.
By their numbers in this assay, from the lowest: compounds 1, 2, 3 and 4 (each within the scatter of the next, the first and the last beyond it).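

In this assay, this result shows that a methyl on the aromatic ring attached to the carbonyl carbon does not count the same wherever it stands: the step of a 2.3-fold higher number from compound 2 to compound 4 (0.35 log units; beyond the scatter) lies beyond the scatter as 3-methylphenyl replaces the plain phenyl ring, whereas the step of a 1.3-fold higher number from compound 1 to compound 2 (0.12 log units; within the scatter), which links the 4-methylphenyl ring to that same plain ring, stays within it. The clearest view comes from the pair that differs only in where the methyl stands, since the step of a 3.0-fold higher number from compound 1 to compound 4 (0.48 log units; beyond the scatter) separates 4-methylphenyl from 3-methylphenyl by more than the scatter, although both groups have the same atoms. The step of a 1.2-fold higher number from compound 3 to compound 4 (0.08 log units; within the scatter) stays within the scatter, so this assay does not tell 2-fluorophenyl and 3-methylphenyl apart, and a fluorine and a methyl on different ring positions can give numbers that cannot be separated.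

No measurement at hand explains why the place of the methyl matters. From the compounds shown here alone, it remains open how 2-methylphenyl or 3-fluorophenyl would compare, and how a chloro, a methoxy, an amine or a carboxylic acid on this ring would read.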